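Lipophilicity notes: fluoro on the pyridin-2-yl group

A few compounds are considered here, and "the series" means these few. Any claim that something is new, unique, unknown or untested is made for them only; others in the source may bear on it.

Measured so far:
compound 1, `Cn1c(COc2cccc(C(=O)O)c2)nc2ccc(Oc3ccc4c(c3)CCC4)nc21`: 2.5
compound 2, `Cn1c(COc2cccc(C(=O)O)c2)nc2ccc(Oc3ccccn3)cc21`: 0.4

In a physicochemical assay for lipophilicity, read by LC-MS, in phosphate buffer, measured as octanol-water partition, with a stated time of 30 min, at pH 7.4, tested at 200 mM (a higher number here means a more lipophilic compound, a lower number a more polar compound), compound 2 stands lowest of the two numbers; compound 1 sits well above it, by a gap beyond the usual scatter. Among the measured compounds shown here, no stepwise pair of measured compounds is available, so only these two values can be compared.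

Compound 3, `Cn1c(COc2cccc(C(=O)O)c2)nc2ccc(Oc3ccc(F)cn3)cc21`, has not been measured. It differs from compound 2 by fluoro in place of hydrogen on an aromatic carbon.

The step of a number 0.20 log units higher from compound 2 to compound 3 (within the scatter) is expected to be small and upward, at most marginally beyond the scatter. For compound 3 the value in this assay is estimated at 0.6, with a range from 0.2 to 1.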

Compound 3, distribution coefficient: 0.6
Compound 3: middle estimate and measured number agree at the digits printed; measured number inside the range.
By their numbers in this assay, from the lowest: compounds 2 and 3 (each within the scatter of the next); then compound 1.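

In this assay, fluoro in place of hydrogen, two atoms from the ring nitrogen and para to a large group, gives a number 0.20 log units higher from compound 2 to compound 3 (within the scatter). Among the compounds shown here, this is the first one-place comparison, and at this position it does not separate 5-fluoropyridin-2-yl from pyridin-2-yl on this read-out. No measurement available here offers an explanation for the size of this step.

From the compounds shown here alone, whether an amine or a methoxy group at this same position would give a step beyond the scatter remains open. Also open, going by these compounds, is whether fluoro on another carbon of this ring would give a similar step.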